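Swapping tert-butyl for 1-methylcyclopropyl on compound 3

The compounds below may be only part of what the source reports. "The series", "measured", "known", "first", "only" and "open" are said of these compounds alone.

Compounds measured so far in a physicochemical assay for solubility, read by LC-MS, at pH 6.8; a lower number here means a less soluble compound, a higher number a more soluble compound

Compound 1 `COc1cc(CN(C)C(=O)c2c(OCCCC3CCN(C(=O)OC(C)(C)C)CC3)c3ccccc3n(C)c2=O)cc(OC)c1` gives 1.8 ug/mL
Compound 2 `COc1cc(CN(C)C(=O)c2c(OCCCC3CCN(C(=O)OC(C)(C)C)CC3)c3cnccc3n(C)c2=O)cc(OC)c1` gives 33 ug/mL
Compound 3 `COc1cc(CN(C)C(=O)c2c(OCCCC3CCN(C(=O)OC(C)(C)C)CC3)c3cccnc3n(C)c2=O)cc(OC)c1` gives 7.3 ug/mL

Compound 3 (7.3 ug/mL) stands second highest of the three, with gaps beyond the scatter to both compound 1 and compound 2. Compound 4 `COc1cc(CN(C)C(=O)c2c(OCCCC3CCN(C(=O)OC4(C)CC4)CC3)c3cccnc3n(C)c2=O)cc(OC)c1` differs from it in one place, with 1-methylcyclopropyl in place of tert-butyl on an oxygen next to a carbonyl group. Among the measured compounds shown here, no measured pair shows this swap, so the expectation is rough: no step beyond the scatter is expected in this assay and perhaps a slight rise. The estimated change is a 1.2-fold higher number from compound 3 to compound 4 (0.09 log units; within the scatter) at the middle of that expectation. Compound 4 is expected near 9 ug/mL as a middle value, with 4 ug/mL and 20 ug/mL as the estimated ends of its range.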

Compound 4, solubility: 16 ug/mL
Compound 4: middle estimate off by 1.8-fold (0.25 log units), on the low side; the measured number falls inside the stated range.
By their numbers in this assay, from the lowest: compound 1; then compound 3; then compound 4; then compound 2.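

In this assay, replacing tert-butyl with 1-methylcyclopropyl on an oxygen next to a carbonyl group gives a 2.2-fold higher number from compound 3 to compound 4 (0.34 log units; beyond the scatter). This modest step shows that the number at this position can move even when the heavy-atom count stays the same, and when the swap adds no hydrogen-bond donor or acceptor. Nothing measured here explains the step.

From the compounds shown here alone, it remains open whether the same swap would give a similar step on the cores of compound 1 and compound 2. Going by these compounds, it is also open how an amine or a longer chain would behave at this position.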